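The source may hold more compounds than are shown below. What is called first, only, known or untested is meant among the compounds shown, and "the series" means these compounds.

Three compounds from this series carry a shared core with a chalcone-like arm, a carbonyl joined through a double bond to an aromatic ring. Compound 1 `COc1ccc(C(=O)/C=C/c2cc(-c3cc(OC)c(OC)c(OC)c3)n3nc(-c4ccccc4)cc3n2)cc1OC` gives 17800 nM in a functional assay on A549 cells (Homo sapiens) for antiproliferative activity, read by MTT assay, with a stated time of 24 h; on this read-out lower numbers stand for stronger inhibition and higher numbers for weaker inhibition. Compound 2 `COc1ccc(-c2cc(/C=C/C(=O)c3ccccc3)nc3cc(-c4ccccc4)nn23)cc1` gives 8600 nM. Compound 3 `COc1cc(-c2cc(/C=C/C(=O)c3ccc(C)cc3)nc3cc(-c4ccccc4)nn23)cc(OC)c1OC` gives 19400 nM, the highest of the three numbers, yet its gap to compound 1 falls within the usual scatter, so the two cannot be told apart on this read-out; only compound 2 sits clearly apart, beyond the scatter.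

Among the measured compounds shown here, the one measured step that touches the aromatic ring on the carbonyl carbon is a 1.1-fold higher number from compound 1 to compound 3 (0.04 log units; within the scatter), a change that left the number essentially where it was.

Compound 4 `COc1cc(-c2cc(/C=C/C(=O)c3ccccc3)nc3cc(-c4ccccc4)nn23)cc(OC)c1OC` differs from compound 3 by a single change: hydrogen in place of methyl on an aromatic carbon. This is a smaller edit than the swap from compound 1 to compound 3, and it sits at the same place. Compound 2 also carries the plain benzoyl, but it differs from compound 4 elsewhere, so its value cannot be read as a step. On this basis the expected step of a 1.3-fold lower number from compound 3 to compound 4 (0.11 log units; within the scatter) is small, with no confident direction. Compound 4 is therefore estimated at 15000 nM, with a range from 6000 nM to 38000 nM.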

Compound 4, half-maximal inhibitory concentration: 18200 nM
Beside the measured number, compound 4's estimate is 1.2-fold (0.08 log units) below it; the range from low to high includes it.
By their numbers in this assay, from the lowest: compound 2; then compounds 1, 4 and 3 (each within the scatter of the next).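

In this assay, with 3,4,5-trimethoxyphenyl held fixed on the shared core, plain phenyl on the carbonyl carbon shows no difference this read-out can detect from the two substituted rings. Losing the methyl gives a 1.1-fold lower number from compound 3 to compound 4 (0.03 log units; within the scatter) and replacing 3,4-dimethoxyphenyl with phenyl gives a 1.0-fold higher number from compound 1 to compound 4 (0.01 log units; within the scatter), both within the scatter. Compound 4 also links to compound 2 at a different place, where 3,4,5-trimethoxyphenyl in place of 4-methoxyphenyl gives a 2.1-fold higher number from compound 2 to compound 4 (0.33 log units; beyond the scatter), a modest step but the only one so far beyond the scatter, which suggests that this other ring matters more here than the ring on the carbonyl carbon. No measurement at hand explains either result.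

Every ring shown on the carbonyl carbon is a phenyl that is bare or carries methyl or methoxy groups, so it remains open whether an amine or a carboxylic acid on that ring would move the number. As far as these compounds go, the step between 4-methoxyphenyl and 3,4,5-trimethoxyphenyl also rests on a single pair with the plain benzoyl arm, so whether it keeps its size with 4-methylphenyl on the carbonyl carbon is unknown.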